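The compounds below may be only part of what the source reports. "The series", "measured", "known", "first", "only" and "open" are said of these compounds alone.

Working notes on the series.

Compound 1, `O=S(=O)(c1cc(F)cc(F)c1)c1cnc2c(F)cccc2c1-c1ccccc1F`, is the reference here. In an ADME assay on microsomes from liver (Homo sapiens) for metabolic stability, tested at 2.5 uM (a higher number here means faster removal of the compound, a lower number slower removal), compound 1 gives 0.09 mL/min, the lowest of the two numbers measured; its nearest neighbour is compound 2, `COc1ccc(-c2c(S(=O)(=O)c3cc(F)cc(F)c3)cnc3c(F)cccc23)cc1`, which in this assay gives 2.59 mL/min, a step of a 29-fold higher number from compound 1 to compound 2 (1.46 log units; beyond the scatter). Going by the values given here, that step changes the aryl group on the aromatic carbon of the shared core and is the only measured step in the set.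

Compound 3, `O=S(=O)(c1ccc(F)c(F)c1)c1cnc2c(F)cccc2c1-c1ccccc1F`, differs from compound 1 at a different place: 3,4-difluorophenyl in place of 3,5-difluorophenyl on a sulfonyl sulfur. Among the compounds with values here, no measured step touches the sulfonyl aryl group, so the single step from compound 1 to compound 2 gives no direct guide, and the same atoms are simply joined differently. With nothing to point the other way, the expectation for compound 3 is a step of about a 1.3-fold higher number from compound 1 to compound 3 (0.12 log units; within the scatter), that is no change beyond the scatter. The expected value for compound 3 in this assay is therefore 0.12 mL/min, with a range from 0.04 mL/min to 0.35 mL/min.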

Compound 3, intrinsic clearance in a liver preparation (reported as CLH), per the amount of preparation that the assay uses: 1.39 mL/min
The estimate for compound 3 lay 12-fold (1.06 log units) below the measured number, outside the stated range (above it).
By their numbers in this assay, from the lowest: compound 1; then compounds 3 and 2 (each within the scatter of the next).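

With 3,4-difluorophenyl in place of 3,5-difluorophenyl on a sulfonyl sulfur, this assay shows a 15-fold higher number from compound 1 to compound 3 (1.19 log units; beyond the scatter), so the sulfonyl aryl group is a second place in the series where the number moves, alongside the aryl group changed in a 29-fold higher number from compound 1 to compound 2 (1.46 log units; beyond the scatter). The two groups have the same heavy atoms and the same counts of hydrogen-bond donors and acceptors, so in this pair a different arrangement of the same atoms is enough for a large step. Nothing available accounts for the size of this step.

Open, from the compounds shown here alone, is whether the low number of compound 1 holds with other groups on the sulfonyl sulfur, such as an unsubstituted phenyl or a 3,5-dichlorophenyl. Also open, going by these compounds, is how the two steps combine when 4-methoxyphenyl and 3,4-difluorophenyl stand on one core.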